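A tert-Butyl Group Where a Biaryl Once Stood

This account rests on a few compounds, and the source may have more. Where it says the series, first, only, none or still open, it means among the compounds named here.

compound 1: `COC(=O)/C=C/c1cccc(N(Cc2ccc(-c3cccc(Cl)c3)cc2)C(=O)C2CCCCC2)c1` — 94 nM
compound 2: `COC(=O)/C=C/c1cccc(N(Cc2ccc(-c3ccc(C(C)(C)C)cc3)cc2)C(=O)C2CCCCC2)c1` — 132 nM
compound 3: `COC(=O)/C=C/c1cccc(N(Cc2ccccc2)C(=O)C2CCCCC2)c1` — > 1000 nM (a limit)

Going by the values given here, compound 3 stands at the edge of an assay on isolated protein with Bile acid receptor (Homo sapiens) as the target; a lower number here means that less compound is needed, a higher number that more compound is needed for the effect: its result, > 1000 nM, is a limit rather than a number, the one value here sitting at the limit of > 1000 nM in this assay, at which 1 of the 3 values shown sits. Compound 1 and compound 2 each carry a biaryl, and the measured steps from them to compound 3 were large: an at least 10-fold higher number from compound 1 to compound 3 (1.02 log units; beyond the scatter) and an at least 7.5-fold higher number from compound 2 to compound 3 (0.87 log units; beyond the scatter). Compound 4, `COC(=O)/C=C/c1cccc(N(Cc2ccc(C(C)(C)C)cc2)C(=O)C2CCCCC2)c1`, makes a smaller move: tert-butyl in place of hydrogen on an aromatic carbon. Among the compounds with values here, no measured step tests a tert-butyl on its own; the two measured steps show only that a larger group on this aromatic carbon goes with a lower number, so a move in that direction is expected, with a step that the limit leaves unreadable from compound 3 to compound 4. Compound 4 is therefore estimated at 1500 nM, in the range 400 nM to 6000 nM, with a fair chance that only a limit is reported again.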

Compound 4, half-maximal effective concentration: > 1000 nM
Compound 4: only a limit was reported; the forecaster's own chance of this, stated with the estimate: 55%; the middle value is on the limit's open side.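

In this assay compound 4 gives > 1000 nM, which is a limit, the same edge that compound 3 reached: the limit of > 1000 nM in this assay, at which 2 of the 4 values shown sit. A tert-butyl alone on this aromatic carbon therefore does not match the biaryl groups, with an at least 10-fold higher number from compound 1 to compound 4 (1.02 log units; beyond the scatter) and an at least 7.5-fold higher number from compound 2 to compound 4 (0.87 log units; beyond the scatter). The step from compound 3 to compound 4 cannot be read, so any difference between tert-butyl and hydrogen here stays hidden.

The compounds shown leave open whether an unsubstituted phenyl on this carbon would already give a measurable number. Also open, from the compounds shown here alone, is how a group such as an amine or a carboxylic acid at the far end of the biaryl would fare.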